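Methyl step on the aromatic ring of the shared core

The source may report more compounds than this note shows. Statements on the series, on what has been measured and on what is new or still open speak of the compounds shown alone.

Measured in a functional assay for agonist activity at Free fatty acid receptor 1 (Homo sapiens), read by FLIPR, in the presence of a further agent that is not named here; a higher number here means that more compound is needed for the effect, a lower number that less compound is needed:
compound 1 `Cc1ccc(C)c(Oc2ccc(CC3SC(=O)NC3=O)cc2)c1`: 238 nM
compound 2 `Cc1ccccc1Oc1ccc(CC2SC(=O)NC2=O)cc1`: 124 nM
compound 3 `O=C1NC(=O)C(Cc2ccc(Oc3ncc(C(F)(F)F)cc3Cl)cc2)S1`: 69 nM

Compound 3 has the lowest number of the three in this assay; its gap to compound 2 is within the scatter, its gap to compound 1 beyond it. The difference between the core of compound 2 and the core of compound 3 is not broken down here.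

One change is seen in measured compounds: methyl in place of hydrogen on an aromatic carbon, which gave a 1.9-fold higher number from compound 2 to compound 1 (0.28 log units; within the scatter). The same kind of change makes compound 4 `Cc1cc(Oc2ncc(C(F)(F)F)cc2Cl)ccc1CC1SC(=O)NC1=O` from compound 3: methyl in place of hydrogen on an aromatic carbon. The place differs: here the entering methyl sits ortho to a (2,4-dioxo-1,3-thiazolidin-5-yl)methyl group, not para to a methyl group.

Because a 1.9-fold higher number from compound 2 to compound 1 (0.28 log units; within the scatter) stayed within the scatter, a similarly small step is expected for compound 4, a 1.6-fold higher number from compound 3 to compound 4 (0.20 log units; within the scatter), in this assay. Compound 4 is estimated at 110 nM, between 45 nM and 280 nM.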

Compound 4, half-maximal effective concentration: 10 nM
Compound 4: middle estimate off by 11-fold (1.04 log units), on the high side; the measured number lies below the stated range.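

In this assay, methyl in place of hydrogen on an aromatic carbon does not carry across cores as one fixed step: the same change on two cores in this assay, a 1.9-fold higher number (0.28 log units; within the scatter) from compound 2 to compound 1 and a 6.9-fold lower number (0.84 log units; beyond the scatter) from compound 3 to compound 4, 13-fold (1.12 log units) apart, beyond the scatter of two such steps

On the core of compound 3, the methyl ortho to a (2,4-dioxo-1,3-thiazolidin-5-yl)methyl group gives a 6.9-fold lower number from compound 3 to compound 4 (0.84 log units; beyond the scatter). The two steps differ in core and also in the place of the methyl, and these pairs do not show which of the two accounts for the gap.

Going by these compounds alone, open is whether a methyl at this same place on the core of compound 2 gives a step like the one to compound 4. Also open, from the compounds shown here alone, is whether an ethyl or methoxy group there would behave as the methyl does.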